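The compounds below may be only part of what the source reports. "The series", "measured", "known", "first", "only" and "open" are said of these compounds alone.

Three compounds share one core and differ only in the group that sits on a carbonyl carbon. Compound 1 `CCn1nc(C)cc1C(=O)Nc1nc2cc(C(N)=O)cc(OC)c2n1CCCNC(=O)OCc1ccccc1` carries a 1-ethyl-3-methyl-1H-pyrazol-5-yl group there, compound 2 `COc1cc(C(N)=O)cc2nc(NC(=O)c3nccc4ccccc34)n(CCCNC(=O)OCc3ccccc3)c12` an isoquinolin-1-yl group, and compound 3 `COc1cc(C(N)=O)cc2nc(NC(=O)c3ccnn3C)n(CCCNC(=O)OCc3ccccc3)c12` a 1-methyl-1H-pyrazol-5-yl group. All three were tested in an assay for activation of interferon regulatory factor 3 (Homo sapiens), read by a luciferase reporter, with a stated time of 20 h; on this read-out lower numbers stand for an effect already at smaller amounts and higher numbers for an effect only at larger amounts of compound. Compound 1 reaches only the limit of the assay, > 100000 nM. Compound 2 likewise stops at the limit, > 100000 nM. Compound 3 also gives only the limit, > 100000 nM. Because all three sit at the limit of > 100000 nM in this assay, at which 3 of the 3 values shown sit, the steps between them cannot be read in size or direction: a step that the two limits leave unreadable from compound 1 to compound 2, a step that the two limits leave unreadable from compound 1 to compound 3 and a step that the two limits leave unreadable from compound 2 to compound 3. Compound 3 therefore stands at a limit and not at a number.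

Compound 4 `COc1cc(C(N)=O)cc2nc(NC(=O)CCc3ccccc3)n(CCCNC(=O)OCc3ccccc3)c12` has not yet been measured. It differs from compound 3 in one place: phenethyl in place of 1-methyl-1H-pyrazol-5-yl on a carbonyl carbon. For the measured compounds named here, none of the measured steps has a readable size, so no direction can be drawn from them; what they do show is that every exchange of this group so far has left the compound at the limit in this assay. The step from compound 3 to compound 4 is expected to be a number no higher from compound 3 to compound 4 (the limit leaves the size open), meaning no change beyond the scatter is expected. Compound 4 is estimated at 100000 nM in this assay, with a range from 30000 nM to 300000 nM, and it is expected that the assay again reports only a limit.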

Compound 4, half-maximal effective concentration: > 100000 nM
Compound 4 ended at the assay's limit; the forecaster's own chance of this, stated with the estimate: 85%; the middle value lies on the limit itself.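

For the compounds shown here, compound 4 also gives only a limit and not a number, so no step from compound 1, compound 2 or compound 3 to compound 4 can be read, because all four compounds stand at the same limit: the limit of > 100000 nM in this assay, at which 4 of the 4 values shown sit. The compounds shown leave open whether any group on this carbonyl carbon would give a measurable value in this assay.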